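Swapping the ether-linked ring on the core of compound 3

A few compounds are considered here, and "the series" means these few. Any claim that something is new, unique, unknown or untested is made for them only; others in the source may bear on it.

Of the compounds shown here, three share one core and have been measured in a physicochemical assay for solubility, with a stated time of 18 h, at pH 7.4; a lower number here means a less soluble compound, a higher number a more soluble compound. Compound 1 `COc1ccc(Oc2ccc3c(NCCCNCc4cc(F)ccc4OC)ccnc3c2)cc1` gives 14500 nM. Compound 2 `COc1ccc(F)cc1CNCCCNc1ccnc2cc(C3CCCCC3)ccc12`, which carries a cyclohexyl in place of 4-methoxyphenoxy on an aromatic carbon, gives 4200 nM; that step is a 3.5-fold lower number from compound 1 to compound 2 (0.54 log units; beyond the scatter). Compound 3 `COc1ccc(Oc2ccc3c(NCCCNCc4cccc(OC)c4O)ccnc3c2)cc1` gives 14500 nM. The change from compound 1 to compound 3, a 2-hydroxy-3-methoxyphenyl in place of 5-fluoro-2-methoxyphenyl on a saturated chain carbon bound to an amine nitrogen, produced no change at the digits printed from compound 1 to compound 3 (within the scatter). Compound 3 thus stands level with compound 1 at the top of the three numbers, with compound 2 the furthest away and lower.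

Compound 4 `COc1cccc(CNCCCNc2ccnc3cc(-c4ccc(C(F)(F)F)cc4)ccc23)c1O` has not yet been measured. Its difference from compound 3 is 4-(trifluoromethyl)phenyl in place of 4-methoxyphenoxy on an aromatic carbon. Among the compounds with values here, the one measured step that bears on this is the exchange on the same aromatic carbon from compound 1 to compound 2, where another ring replaced the 4-methoxyphenoxy and the number fell. A step of similar character is therefore expected here, downward, beyond the scatter: the expected change is a 4.8-fold lower number from compound 3 to compound 4 (0.68 log units; beyond the scatter). Compound 4 is estimated to give 3000 nM in this assay, within a range from 900 nM to 9000 nM.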

Compound 4, solubility: 32000 nM
Beside the measured number, compound 4's estimate is 11-fold (1.03 log units) below it; measured number outside the range, above it.
By their numbers in this assay, from the lowest: compound 2; then compounds 1 and 3 (each within the scatter of the next); then compound 4.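

In this assay, losing the 4-methoxyphenoxy from this aromatic carbon does not have to lower the number: putting 4-(trifluoromethyl)phenyl there gives a 2.2-fold higher number from compound 3 to compound 4 (0.34 log units; beyond the scatter), while cyclohexyl at the same carbon gave a 3.5-fold lower number from compound 1 to compound 2 (0.54 log units; beyond the scatter). The direction of a change at this position is therefore not fixed by the group that leaves, even though the two steps remove the same 4-methoxyphenoxy. These steps differ both in the group that enters and in the ring at the far end of the side chain, and no measurement shown here explains the rise or separates those two differences.

As far as these compounds go, it remains open whether 4-(trifluoromethyl)phenyl would bring a similar rise on the 5-fluoro-2-methoxyphenyl side chain of compound 1, and whether cyclohexyl would bring a fall on the 2-hydroxy-3-methoxyphenyl side chain of compound 3. Also open, from the compounds shown here alone, is how the number would respond on this aromatic carbon to a plain phenyl, or to a phenyl ring carrying an amine or a carboxylic acid in place of the trifluoromethyl.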